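This account rests on a few compounds, and the source may have more. Where it says the series, first, only, none or still open, it means among the compounds named here.

Measured compounds:
Compound 1 `C[C@@H](Cn1ccc(-c2ccc(C#N)c(Cl)c2)n1)NS(=O)(=O)c1cccnc1` — in an ADME assay on PC-3 cells (Homo sapiens) for cytotoxicity, read by CCK-8 assay, with a stated time of 6 days (on this read-out lower numbers stand for stronger inhibition and higher numbers for weaker inhibition), compound 1 gives only the assay limit > 30000 nM.
Compound 2 `C[C@@H](Cn1ccc(-c2ccc(C#N)c(Cl)c2)n1)NS(=O)(=O)c1cn(C)cn1` — in this assay compound 2 likewise gives only the assay limit > 30000 nM.

Compound 2 therefore stands at the limit, with no number of its own, and the same holds for compound 1; both values sit at the limit of > 30000 nM in this assay, at which 2 of the 2 values shown sit. Going by the values given here, the single step between them, a step that the two limits leave unreadable from compound 1 to compound 2, gives no readable size.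

Compound 3 `C[C@@H](Cn1ccc(-c2ccc(C#N)c(Cl)c2)n1)Nc1ccccc1` differs from compound 2 by phenyl in place of (1-methyl-1H-imidazol-4-yl)sulfonyl on an amine nitrogen. Among the compounds with values here, no measured step bears on this change: the one recorded step concerns the sulfonyl group and its size cannot be read. With both measured compounds at the limit, compound 3 is expected to stay at or near it, and the step that the limit leaves unreadable from compound 2 to compound 3 is an estimate only. Compound 3 is expected to give 40000 nM, within 10000 nM to 150000 nM, most likely reported as a limit once more.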

Compound 3, half-maximal inhibitory concentration: 3210 nM
Compound 3: middle estimate off by 12-fold (1.10 log units), on the high side, and the stated range ends above it.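

On the amine nitrogen, phenyl in place of (1-methyl-1H-imidazol-4-yl)sulfonyl gives an at least 9.3-fold lower number from compound 2 to compound 3 (0.97 log units; beyond the scatter) in this assay, and phenyl in place of (pyridin-3-yl)sulfonyl gives an at least 9.3-fold lower number from compound 1 to compound 3 (0.97 log units; beyond the scatter). This position therefore does affect the read-out, which the two sulfonyl compounds alone could not show, and compound 3 is the only one of the three with a number of its own. Both steps are lower bounds, and the step from compound 1 to compound 2 cannot be read, as both sulfonyl compounds rest at a limit: the limit of > 30000 nM in this assay, at which 2 of the 3 values shown sit.

The compounds shown do not separate the effect of losing the sulfonyl link from that of gaining the phenyl ring, which a phenylsulfonyl group on this nitrogen would address. Going by these compounds, how substituents on the phenyl, such as fluoro or methoxy, or a benzyl group in its place would read also remains open.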